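Chloro to fluoro swaps and Vero cell tolerance

This account rests on a few compounds, and the source may have more. Where it says the series, first, only, none or still open, it means among the compounds named here.

Measured so far:
- compound 1 `O[C@@H]1Cc2cc(Cl)ccc2N[C@H](c2ccccc2)C1` gives 191000 nM in an ADME assay on Vero cells (Chlorocebus sabaeus) for cytotoxicity, read by MTT assay, with a stated time of 72 h; a lower number here means that less compound is tolerated, a higher number that more compound is tolerated.
- compound 2 `O[C@@H]1Cc2cc(F)ccc2N[C@H](c2ccccc2)C1` reaches only the limit > 300000 nM in this assay.
- compound 3 `O[C@@H]1Cc2ccccc2N[C@H](c2ccccc2Cl)C1` likewise reaches only the limit > 300000 nM in this assay.

Going by the values given here, the one measured step is fluoro in place of chloro on an aromatic carbon, which gives an at least 1.5-fold higher number from compound 1 to compound 2 (0.19 log units; that floor lies within the scatter). From the compounds shown here alone, that step is bounded by the limit of > 300000 nM in this assay, at which 2 of the 3 values shown sit, so its true size is unknown. How the cores of compound 1 and compound 3 differ is not broken down here.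

Compound 4 `O[C@@H]1Cc2ccccc2N[C@H](c2ccccc2F)C1` is not yet measured. It differs from compound 3 by fluoro in place of chloro on an aromatic carbon, the same kind of change as that from compound 1 to compound 2, but at a different place: in the earlier pair the carbon sits in a ring that is part of a fused or bridged system of two rings, meta and para to a fused ring, whereas here it sits in a ring of carbon only, ortho to a large group.

Since compound 3 already sits at the limit in this assay, and the earlier swap did not lower the number, compound 4 is expected to sit at the limit as well, an estimated step that the limit leaves unreadable from compound 3 to compound 4. The estimate for compound 4 is 350000 nM, between 150000 nM and 900000 nM.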

Compound 4, half-maximal cytotoxic concentration: > 300000 nM
Compound 4: no number, only a limit; the forecaster's own chance of this, stated with the estimate: 75%; the middle value lies beyond the limit too.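

Compound 3 and compound 4 both stop at a limit in this assay, so fluoro in place of chloro gives no readable step between them: the limit of > 300000 nM in this assay, at which 3 of the 4 values shown sit.

The compounds shown leave open where compound 2, compound 3 and compound 4 truly lie beyond that limit, and so how large the effect of this swap is at either place.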